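Shortening the alkyl chain on the shared core

A few compounds are considered here, and "the series" means these few. Any claim that something is new, unique, unknown or untested is made for them only; others in the source may bear on it.

Of the compounds shown here, two have been measured so far. Compound 1 `CCCCc1c(OC)nc2nc(C(=O)c3ccccc3)cn2c1C` carries a butyl and a methyl on the shared core and gives, in a functional assay on the whole organism with Rattus norvegicus as the target (on this read-out lower numbers stand for an effect already at smaller amounts and higher numbers for an effect only at larger amounts of compound), a value of 2 mg/kg. Compound 2 `CCc1cc(OC)nc2nc(C(=O)c3ccccc3)cn12` carries an ethyl in place of the butyl and lacks the methyl; in this assay compound 2 gives 2 mg/kg. Compound 2 thus stands level with compound 1 at the digits shown, the two values lying within the scatter of each other, so the longer chain with its added methyl and the shorter chain without it read the same here.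

The next step leads from compound 2 to compound 3 `COc1cc(C)n2cc(C(=O)c3ccccc3)nc2n1`, which is not yet measured in this assay. The change is a single one: hydrogen in place of methyl on a saturated chain carbon bound to an aromatic carbon. Going by the values given here, no step between measured compounds is available to calibrate it; the only guidance is that compound 1 and compound 2, which differ by more than this, sit at the same level.

Against that background the step from compound 2 to compound 3 is expected to stay within the scatter, perhaps edging toward a slightly larger dose, as a 1.5-fold higher number from compound 2 to compound 3 (0.18 log units; within the scatter). Compound 3 is therefore estimated at 3 mg/kg, with a range from 1 mg/kg to 8 mg/kg.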

Compound 3, minimum effective dose: 5 mg/kg
Compound 3: the middle estimate sits 1.7-fold (0.22 log units) below what was measured; measured number inside the range.
By their numbers in this assay, from the lowest: compounds 1 and 2 (each within the scatter of the next); then compound 3.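

In this assay the change from ethyl to methyl, with hydrogen in place of methyl on a saturated chain carbon bound to an aromatic carbon, gives a 2.5-fold higher number from compound 2 to compound 3 (0.40 log units; beyond the scatter) and is thus the first difference in this series to lie beyond the scatter, though only a modest one. The step for hydrogen in place of butyl on an aromatic carbon, a 2.5-fold higher number from compound 1 to compound 3 (0.40 log units; beyond the scatter) in the same read-out, is of the same printed size, so the methyl of compound 3 stands apart from both the ethyl of compound 2 and the butyl of compound 1, while those two remain level with each other. The data at hand offer no independent measurement that could explain this shift.

On these data alone, whether a chain longer than butyl stays level with compound 1 remains open, and so does the question of whether the higher number of compound 3 holds across other cores of the series. As far as these compounds go, it is equally open how a propyl, a cyclopropyl, or a chain ending in an amine or a carboxylic acid would read in place of the ethyl of compound 2 in this assay on this read-out.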